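The source may report more compounds than this note shows. Statements on the series, on what has been measured and on what is new or still open speak of the compounds shown alone.

Measured so far in an assay on HEK-293T cells for antagonist activity at vitamin D3 receptor (Homo sapiens), read by a luciferase reporter, with a stated time of 24 h; on this read-out lower numbers stand for stronger inhibition and higher numbers for weaker inhibition:
compound 1 `CC(C)c1onc(-c2c(Cl)cccc2Cl)c1COc1ccc(-c2nc3ccc(C(=O)O)cc3n2Cc2ccc(F)cc2)cc1`: 1140 nM
compound 2 `CC(C)c1onc(-c2c(Cl)cccc2Cl)c1COc1ccc(-c2nc3cc(C(=O)O)ccc3n2C)cc1`: 4410 nM
compound 3 `CC(C)c1onc(-c2c(Cl)cccc2Cl)c1COc1ccc(-c2nc3ccc(C(=O)O)cc3n2CC2CCCCC2)c(F)c1`: 840 nM

Compound 1 sits second highest of the three numbers. Its nearest neighbour is compound 3, whose number is lower by an amount within the scatter, so the two cannot be told apart on this read-out. Within the data shown here, compound 2 stands furthest from compound 1, with a number higher by a margin beyond the scatter; compound 2 differs from compound 1 in more than one place, so no single step between them is defined and only the two values themselves can be compared.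

Compound 4 `CC(C)c1onc(-c2c(Cl)cccc2Cl)c1COc1ccc(-c2nc3ccc(C(=O)O)cc3n2C2CC2)cc1` is the next case. Relative to compound 1 it carries cyclopropyl in place of 4-fluorobenzyl on an aromatic nitrogen. Among the measured compounds shown here, no pair among the measured compounds differs in this place alone, so the size of this step has no anchor. For the measured compounds named here, what can be said is that the one compound with a different group on the ring nitrogen and no benzyl-type chain, compound 2, gives 4410 nM, though the carboxylic acid also sits differently there. A modest loss is therefore expected for compound 4, as a step of a 1.9-fold higher number from compound 1 to compound 4 (0.29 log units; within the scatter), with wide uncertainty. For compound 4 the estimate in this assay is 2200 nM, within a range from 800 nM to 6000 nM.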

Compound 4, half-maximal inhibitory concentration: 3200 nM
The estimate for compound 4 lay 1.5-fold (0.16 log units) below the measured number, and the stated range covers the measured number.
By their numbers in this assay, from the lowest: compounds 3 and 1 (each within the scatter of the next); then compounds 4 and 2 (each within the scatter of the next).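

In this assay, among these compounds, cyclopropyl in place of 4-fluorobenzyl on the aromatic nitrogen gives a 2.8-fold higher number from compound 1 to compound 4 (0.45 log units; beyond the scatter), the only single-place step so far, and it lies beyond the scatter. The group on this nitrogen therefore bears on the read-out: replacing the 8 heavy atoms and six-membered aromatic ring of 4-fluorobenzyl with the 3 heavy atoms and three-membered ring of cyclopropyl weakens inhibition modestly without abolishing it. No measurement on these compounds accounts for the step, so it stands as an observation only.

One step cannot show whether the loss follows the aromatic ring or the smaller number of heavy atoms; an n-butyl chain or a phenyl directly on this nitrogen, with the rest of compound 1 unchanged, would help to separate the two. Also open, as far as these compounds go, is how this position responds to a group that brings in a hydrogen-bonding function, such as an amine at the end of a longer chain.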